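The source may hold more compounds than are shown below. What is called first, only, known or untested is meant among the compounds shown, and "the series" means these compounds.

Series notes: three vinyl sulfones on the shared catechol-bearing core, characterised in a functional assay, read by fluorescence and spectrophotometry, with a stated time of 1 h (a higher number here means that more compound is needed for the effect, a lower number that less compound is needed), with a fourth not yet measured.

Compound 1 `C=CCCCCCCS(=O)(=O)/C=C/c1ccc(O)c(O)c1` gives 6400 nM in this assay. Compound 2 `O=S(=O)(/C=C/c1ccc(O)c(O)c1)CCC1CCCC1` gives 6800 nM in this assay. Compound 3 `O=S(=O)(/C=C/c1ccc(O)c(O)c1)CC1CCCC1` gives 9400 nM in this assay. The steps among these three all stay within the scatter: a 1.1-fold lower number from compound 2 to compound 1 (0.03 log units; within the scatter), a 1.5-fold higher number from compound 1 to compound 3 (0.17 log units; within the scatter), a 1.4-fold higher number from compound 2 to compound 3 (0.14 log units; within the scatter). No order among compounds 1, 2 and 3 can be read from these numbers.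

Compound 4 `C=CCCCCCS(=O)(=O)/C=C/c1ccc(O)c(O)c1` is the next one to be measured. It differs from compound 3 by hex-5-en-1-yl in place of cyclopentyl on a saturated chain carbon bound to a sulfonyl sulfur. The same kind of change is already covered by the measured pair, (hex-5-en-1-yl in place of cyclopentyl on a saturated chain carbon, two bonds along the chain from a sulfonyl sulfur), where the place is a saturated chain carbon two bonds along the chain from the sulfonyl sulfur rather than one bound to it; that change gave a 1.1-fold lower number from compound 2 to compound 1 (0.03 log units; within the scatter). The two cores differ as cyclopentyl in place of cyclopentylmethyl on a saturated chain carbon bound to a sulfonyl sulfur.

Given that the earlier step from compound 2 to compound 1 sat within the scatter, compound 4 is expected to show a step of a 1.1-fold lower number from compound 3 to compound 4 (0.04 log units; within the scatter) from compound 3. Compound 4 is estimated at 8500 nM in this assay, with a plausible range of 4000 nM to 18000 nM.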

Compound 4, half-maximal effective concentration: 7100 nM
Beside the measured number, compound 4's estimate is 1.2-fold (0.08 log units) above it; the measured number falls inside the stated range.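

Replacing cyclopentyl with hex-5-en-1-yl gives steps that agree on the two cores in this assay: the same change on two cores in this assay, a 1.1-fold lower number (0.03 log units; within the scatter) from compound 2 to compound 1 and a 1.3-fold lower number (0.12 log units; within the scatter) from compound 3 to compound 4, 1.2-fold (0.10 log units) apart, within the scatter of two such steps

The new step, a 1.3-fold lower number from compound 3 to compound 4 (0.12 log units; within the scatter), stays within the scatter, as do a 1.0-fold higher number from compound 2 to compound 4 (0.02 log units; within the scatter) and a 1.1-fold higher number from compound 1 to compound 4 (0.05 log units; within the scatter), so no order among the four compounds can be read. The agreement between the two cores is therefore one between two steps that cannot be told from the scatter: it shows no sign of the change behaving differently on these two cores, but it does not show that the change moves the number at all, and two cores do not speak for the whole series.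

All the groups shown on the saturated chain carbon bound to a sulfonyl sulfur are hydrocarbons. Going by these compounds, whether an amine or a carboxylic acid in that place would give a step beyond the scatter, and whether such a step would carry from one core to another, remains open.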